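A few compounds are considered here, and "the series" means these few. Any claim that something is new, unique, unknown or untested is made for them only; others in the source may bear on it.

In a functional assay (aorta) with Rattus norvegicus as the target (on this read-out lower numbers stand for stronger inhibition and higher numbers for weaker inhibition), compound 1 `CC1(C)Oc2ccc(C#N)cc2[C@@H](/N=C(\NC#N)Nc2ccc(Cl)cc2)[C@@H]1O` gives 1800 nM and compound 2 `CC1(C)Oc2ccc(C#N)cc2[C@@H](/N=C(\NC#N)Nc2ccccc2)[C@@H]1O` gives 1400 nM; 1300 nM (2 entries). Compound 3 `CC1(C)Oc2ccc(C#N)cc2[C@@H](/N=C(\NC#N)Nc2cccc(Cl)c2)[C@@H]1O` gives 600 nM, the lowest number in the set. For the measured compounds named here, the one measured step, a 3.0-fold lower number from compound 1 to compound 3 (0.48 log units; beyond the scatter), moved the chlorine, with 3-chlorophenyl in place of 4-chlorophenyl on an amine nitrogen. Compound 4 `CC1(C)Oc2ccc(C#N)cc2[C@@H](/N=C(\NC#N)Nc2cccc([N+](=O)[O-])c2)[C@@H]1O` keeps that position but has nitro in place of chloro on an aromatic carbon. Going by the values given here, no measured step exchanges one such group for another, so a 3.0-fold lower number from compound 1 to compound 3 (0.48 log units; beyond the scatter) bears on this change only indirectly, and no step beyond the scatter is expected in this assay, in either direction. The expected change is a 1.1-fold higher number from compound 3 to compound 4 (0.03 log units; within the scatter). Compound 4 is estimated at 650 nM, with an expected range from 250 nM to 1700 nM.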

Compound 4, half-maximal inhibitory concentration: 670 nM
For compound 4 the middle estimate is 1.0-fold (0.01 log units) below the measured one; the measured number falls inside the stated range.
By their numbers in this assay, from the lowest: compounds 3 and 4 (each within the scatter of the next); then compound 1.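

In this assay, nitro in place of chloro gives a 1.1-fold higher number from compound 3 to compound 4 (0.05 log units; within the scatter), so this position holds either group without a step beyond the scatter. The advantage over the 4-chlorophenyl compound persists with a 2.7-fold lower number from compound 1 to compound 4 (0.43 log units; beyond the scatter), which shows that in these compounds it does not depend on chlorine itself. Nothing shown here explains why the two groups read alike. The compounds shown leave open whether an amine or a carboxylic acid at this position would keep the number, and how 4-nitrophenyl would compare with 3-nitrophenyl.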